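Swapping the Ester Tail: Expected Liver Microsome Half-Life

A few compounds are considered here, and "the series" means these few. Any claim that something is new, unique, unknown or untested is made for them only; others in the source may bear on it.

Compound 1 `CCOc1cc(NC(=O)C2(NC(=O)c3ccc4c(C5CCCC5)c(-c5ncc(Cl)cn5)n(C)c4c3)CCC2)ccc1/C=C/C(=O)OCOP(=O)(O)O` gives 0.15 h in an ADME assay (liver) for pharmacokinetics, with Liver microsome (Rattus norvegicus) as the target, using microsomes; on this read-out lower numbers stand for a shorter-lived compound and higher numbers for a longer-lived compound.
Compound 2 `CCOc1cc(NC(=O)C2(NC(=O)c3ccc4c(C5CCCC5)c(-c5ncc(Cl)cn5)n(C)c4c3)CCC2)ccc1/C=C/C(=O)OCC(Cl)(Cl)Cl` gives 0.233 h in this assay.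

Compound 2 has the highest of the two numbers, though its gap to compound 1 lies within the scatter. Compound 3 `CCOc1cc(NC(=O)C2(NC(=O)c3ccc4c(C5CCCC5)c(-c5ncc(Cl)cn5)n(C)c4c3)CCC2)ccc1/C=C/C(=O)OCc1ccccc1` differs from compound 2 by phenyl in place of trichloromethyl on a saturated chain carbon bound to an oxygen next to a carbonyl group. For the measured compounds named here, the one measured step at this place, a 1.6-fold higher number from compound 1 to compound 2 (0.19 log units; within the scatter), was within the scatter, so nothing measured points to a change beyond it. Compound 3 is therefore expected to give 0.22 h, within 0.09 h to 0.55 h, an expected step of a 1.1-fold lower number from compound 2 to compound 3 (0.02 log units; within the scatter).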

Compound 3, half-life: 2.17 h
Estimate against measurement, compound 3: 9.9-fold (0.99 log units) below; the measured number lies above the stated range.
By their numbers in this assay, from the lowest: compounds 1 and 2 (each within the scatter of the next); then compound 3.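

In this assay this ester position proves able to shift the number well beyond the scatter: phenyl in place of trichloromethyl gives a 9.3-fold higher number from compound 2 to compound 3 (0.97 log units; beyond the scatter). Against the phosphorus-bearing tail, the benzyl ester gives a 14-fold higher number from compound 1 to compound 3 (1.16 log units; beyond the scatter), so among these three only the tail with the aromatic ring stands apart. Nothing shown here explains why this ester lasts longer. Going by these compounds, whether the carbon ring itself is needed remains open, since a cyclohexyl or simple ethyl group could behave alike. On these data alone, how a pyridine ring or a fluorine on the phenyl would fare also remains unknown.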